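The source may hold more compounds than are shown below. What is called first, only, known or untested is meant among the compounds shown, and "the series" means these compounds.

Three compounds sharing one core were tested in a functional assay on NCI-H23 cells (Homo sapiens) for cytotoxicity, read by sulforhodamine B assay, with a stated time of 72 h; on this read-out lower numbers stand for stronger inhibition of growth and higher numbers for weaker inhibition of growth. Compound 1, `O=C(Nc1ccccc1C(F)(F)F)C1CCc2ccccc2N1C(=O)c1cccc(Cl)c1`, gives 292 nM. Compound 2, `O=C(Nc1ccccc1C(F)(F)F)C1CCc2ccccc2N1C(=O)c1ccccc1`, gives 6340 nM. Compound 3, `O=C(Nc1ccccc1C(F)(F)F)C1CCc2ccccc2N1C(=O)c1ccccc1Cl`, gives 2150 nM. Compound 2 therefore stands at the weakest end of the three: the step of a 22-fold higher number from compound 1 to compound 2 (1.34 log units; beyond the scatter) and the step of a 2.9-fold lower number from compound 2 to compound 3 (0.47 log units; beyond the scatter) both set it apart, as does the step of a 7.4-fold higher number from compound 1 to compound 3 (0.87 log units; beyond the scatter) between the other two.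

Compound 4, `O=C(Nc1ccccc1O)C1CCc2ccccc2N1C(=O)c1ccccc1`, has not yet been measured. It differs from compound 2 in one place: hydroxy in place of trifluoromethyl on an aromatic carbon. Within the data shown here, none of the measured steps touches this part of the molecule; all three concern the chloro on the ring attached to the carbonyl, so they give no direct guide to how the ring bearing the amide nitrogen responds to change. The size and direction of the coming step in this assay are therefore open, and a wide range is the honest expectation. The step from compound 2 is estimated as a 1.3-fold higher number from compound 2 to compound 4 (0.10 log units; within the scatter). Compound 4 is expected to give about 8000 nM, with a range from 1500 nM to 40000 nM.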

Compound 4, concentration for 50% growth inhibition: 3490 nM
Compound 4: middle estimate off by 2.3-fold (0.36 log units), on the high side; low and high end bracket the measured number.
By their numbers in this assay, from the lowest: compound 1; then compounds 3, 4 and 2 (each within the scatter of the next, the first and the last beyond it).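

In this assay, the first change shown to the 2-(trifluoromethyl)phenyl group does not give a step beyond the scatter (a 1.8-fold lower number from compound 2 to compound 4 (0.26 log units; within the scatter)). At this place, on an aromatic carbon ortho to a large group, hydroxy can therefore replace trifluoromethyl, although the number of heavy atoms falls from 4 to 1 and a hydrogen-bond donor enters. The chloro changes on the other aromatic ring behave differently, each giving a step beyond the scatter, such as (a 22-fold higher number from compound 1 to compound 2 (1.34 log units; beyond the scatter)). No measurement at hand explains this outcome.

Going by these compounds, whether an amine, a methoxy group or a fluoro at this same place would also stay within the scatter remains open. Also open, on these data alone, is whether hydroxy in place of trifluoromethyl would give a similar step with the 3-chlorophenyl group of compound 1 on the carbonyl.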